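The source may hold more compounds than are shown below. What is called first, only, known or untested is meant among the compounds shown, and "the series" means these compounds.

Measured so far:
- Compound 1 `Nc1nc(Cl)c2ncn(Cc3ccc(CCl)cc3)c2n1` gives 10200 nM in a functional assay on NCI-H226 cells (Homo sapiens) for cytotoxicity, read by sulforhodamine B assay, with a stated time of 48 h; a higher number here means a weaker inhibitor of growth, a lower number a stronger inhibitor of growth.
- Compound 2 `ClCc1cccc(Cn2cnc3nc(Cl)nc(Cl)c32)c1` gives 1280 nM in this assay.

Compound 2 has the lowest of the two numbers, and compound 1 sits well beyond the scatter from it. The unmeasured compound 3 `ClCc1cccc(Cn2cnc3ncnc(Cl)c32)c1` differs from compound 2 in one place: hydrogen in place of chloro on an aromatic carbon. Among the measured compounds shown here, no measured pair shows this exact change, so its size is uncertain. Taking away a substituent from the core is expected to cost some activity, so the step of a 2.3-fold higher number from compound 2 to compound 3 (0.37 log units; beyond the scatter) is estimated to be modest but beyond the scatter. For compound 3 the estimate is 3000 nM, with a range from 1000 nM to 9000 nM.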

Compound 3, concentration for 50% growth inhibition: 3160 nM
The estimate for compound 3 lay 1.1-fold (0.02 log units) below the measured number, and the stated range covers the measured number.
By their numbers in this assay, from the lowest: compound 2; then compound 3; then compound 1.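

Taking away the chloro group that sits between two ring nitrogen atoms gives a 2.5-fold higher number from compound 2 to compound 3 (0.39 log units; beyond the scatter) in this assay, so in this pair the chloro group goes with stronger inhibition of growth. Among the compounds shown here, compound 1 and compound 2 differ in more than one place, so only this pair isolates a single change on the core. No measurement here offers a reason for the step. From the compounds shown here alone, whether a methyl or methoxy group on this carbon would match chloro remains open. Also open, going by these compounds, is whether a larger group there would keep the activity.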